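This account rests on a few compounds, and the source may have more. Where it says the series, first, only, none or still open, it means among the compounds named here.

For the measured compounds named here, compound 2 `COC(=O)C(Cc1cccc(C(=N)N)c1)C(/C=C/c1ccccc1)NC(=O)c1ccc(-c2cccc(OC)c2)cc1` gives 2200 nM in an assay on isolated protein (Oryctolagus cuniculus) for inhibition of Trypsin (Homo sapiens) (a lower number here means a stronger inhibitor, a higher number a weaker inhibitor), the lowest of the two numbers so far, with compound 1 `COC(=O)C(Cc1cccc(C(=N)N)c1)C(/C=C/c1ccccc1)NC(=O)c1ccc(-c2ccccc2C)cc1` nearest at 3100 nM; the two lie within the scatter of each other. Compound 3 `COC(=O)C(Cc1cccc(C(=N)N)c1)C(/C=C/c1ccccc1)NC(=O)c1ccc(-c2ccc(OC)cc2OC)cc1` carries 2,4-dimethoxyphenyl in place of 3-methoxyphenyl on an aromatic carbon. Going by the values given here, the only measured step on this part of the series, a 1.4-fold lower number from compound 1 to compound 2 (0.15 log units; within the scatter), stayed within the scatter, and no step with a second methoxy group has been measured. A change beyond the scatter is therefore not expected for compound 3, for which the estimate is 2200 nM (range 900 nM to 5500 nM), an expected step of no change at the digits printed from compound 2 to compound 3 (within the scatter).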

Compound 3, half-maximal inhibitory concentration: 2900 nM
Estimate against measurement, compound 3: 1.3-fold (0.12 log units) below; low and high end bracket the measured number.
By their numbers in this assay, from the lowest: compounds 2, 3 and 1 (each within the scatter of the next).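

In this assay, 2,4-dimethoxyphenyl in place of 3-methoxyphenyl gives a 1.3-fold higher number from compound 2 to compound 3 (0.12 log units; within the scatter) and in place of 2-methylphenyl gives a 1.1-fold lower number from compound 1 to compound 3 (0.03 log units; within the scatter) as the second comparison. At this position, para to a large group, adding a second methoxy group therefore moves the number no further than the scatter, and all three aryl groups remain within the scatter of each other. No available evidence accounts for this flat result.

Open, as far as these compounds go, is whether an amine or a carboxylic acid on this ring would give a step beyond the scatter.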